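Cyclopentyl for Ethyl on the Piperazine of Compound 1

The source may hold more compounds than are shown below. What is called first, only, known or untested is meant among the compounds shown, and "the series" means these compounds.

Working notes on the series. Compound 1 `CCN1CCN(c2nc(NCc3ccc(F)cc3)nc3c2ncn3CCCN2CCCC2)CC1` is the reference point. In an assay on HEK293 cells for antagonist activity at Toll-like receptor 8 (Homo sapiens), read by spectrophotometry (on this read-out lower numbers stand for stronger inhibition and higher numbers for weaker inhibition), compound 1 gives only a limit, > 30000 nM. Compound 2 `CCN1CCN(c2nc(NCc3ccc(OC)cc3)nc3c2ncn3CCCN2CCCC2)CC1` carries methoxy in place of fluoro on an aromatic carbon. In this assay compound 2 also gives only a limit, > 30000 nM. The step that the two limits leave unreadable from compound 1 to compound 2 is thus unreadable, and both values sit at the limit of > 30000 nM in this assay, at which 2 of the 2 values shown sit. Compound 1 therefore stands at the limit of this assay, with no number to place it against any other compound.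

Compound 3 `Fc1ccc(CNc2nc(N3CCN(C4CCCC4)CC3)c3ncn(CCCN4CCCC4)c3n2)cc1` is not yet measured. It differs from compound 1 by cyclopentyl in place of ethyl on an amine nitrogen in a ring. Among the compounds with values here, no measured step touches this position; the only measured step in the set, on the aromatic ring, is itself unreadable and gives no size to draw on. The expected step in this assay is a step that the limit leaves unreadable from compound 1 to compound 3, with no direction supported by the data. Compound 3 is estimated at 40000 nM, within 10000 nM to 150000 nM, and is expected most likely to return only a limit again.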

Compound 3, half-maximal inhibitory concentration in the Toll-like receptor 8 assay: > 30000 nM
Compound 3 ended at the assay's limit (the forecaster's own chance of this, stated with the estimate: 75%); the middle value does not contradict the limit.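

In the Toll-like receptor 8 assay compound 3 returns only a limit (> 30000 nM). In the Toll-like receptor 8 assay compound 1 also returns only a limit (> 30000 nM). No step between the two can be read: the limit of > 30000 nM in the Toll-like receptor 8 assay, at which 3 of the 3 values shown sit.

In a physicochemical assay for solubility, with a stated time of 18 h, at pH 7.4 (on this read-out higher numbers stand for higher solubility and lower numbers for lower solubility), compound 1 gives 218 ug/mL and compound 3 gives 28 ug/mL with cyclopentyl in place of ethyl on an amine nitrogen in a ring: the measured solubility of compound 1, 218 ug/mL, and of compound 3, 28 ug/mL, a 7.8-fold lower number (0.89 log units; beyond the scatter)

Whether any group on the amine nitrogen in a ring, or on the aromatic ring, gives a measurable number in the Toll-like receptor 8 assay is left open by the compounds shown.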